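Hydroxy to carbamoyl on the aryl amine of compound 1

The source may hold more compounds than are shown below. What is called first, only, known or untested is meant among the compounds shown, and "the series" means these compounds.

Among the measured compounds shown here, compound 1 `Oc1cccc(NCCCN2CCN(c3ccccc3)CC2)c1` is the lower of the two numbers so far: in an assay on HEK293 cells for displacement of a labelled ligand from 5-hydroxytryptamine receptor 7 (Homo sapiens), read by scintillation counting, with a stated time of 30 min (a higher number here means a weaker inhibitor, a lower number a stronger inhibitor), compound 1 gives 10.1 nM. Its nearest neighbour, compound 2 `CN(CCCN1CCN(c2ccccc2)CC1)c1cccc(O)c1`, carries a methyl on the amine nitrogen and in this assay compound 2 gives 20 nM; the step of a 2.0-fold higher number from compound 1 to compound 2 (0.30 log units; within the scatter) lies within the scatter. The unmeasured compound 3 `NC(=O)c1cccc(NCCCN2CCN(c3ccccc3)CC2)c1` differs from compound 1 in a different way: carbamoyl in place of hydroxy on an aromatic carbon. For the measured compounds named here, no measured step touches this position on the aromatic ring, since the only step available, that from compound 1 to compound 2, changes a nitrogen substituent and not the ring group. The expectation therefore rests on the unchanged core alone, and a modest weakening is expected as the step of a 4.0-fold higher number from compound 1 to compound 3 (0.60 log units; beyond the scatter). Compound 3 is estimated in this assay at 40 nM, with a range from 8 nM to 200 nM.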

Compound 3, inhibition constant: 63.3 nM
For compound 3 the middle estimate is 1.6-fold (0.20 log units) below the measured one; the range from low to high includes it.
By their numbers in this assay, from the lowest: compounds 1 and 2 (each within the scatter of the next); then compound 3.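

Among the compounds shown here, the ring group of compound 1 matters in a way the earlier compounds could not show: in this assay, putting carbamoyl in place of hydroxy on this aromatic carbon gives a 6.3-fold higher number from compound 1 to compound 3 (0.80 log units; beyond the scatter), whereas the change on the nitrogen gave a 2.0-fold higher number from compound 1 to compound 2 (0.30 log units; within the scatter). Hydroxy and carbamoyl have the same counts of hydrogen-bond donors and acceptors, so a match in those counts does not keep the number at the level of compound 1. Nothing in the available data accounts for this step.

The compounds shown leave open how an amine, a methoxy group or a carboxylic acid on this same aromatic carbon would compare with hydroxy and carbamoyl. They also leave open whether a methyl on the nitrogen would have the same effect with carbamoyl on the ring as with hydroxy.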